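Reinstating a piperazinylmethyl on the core of compound 2

The compounds below may be only part of what the source reports. "The series", "measured", "known", "first", "only" and "open" are said of these compounds alone.

Measured in a functional assay on LNCaP cells (Homo sapiens) for cytotoxicity; a lower number here means a stronger inhibitor, a higher number a weaker inhibitor:
Compound 1 `CN1CCN(Cc2cc3nc(-c4ccc(NC(=O)Nc5ccncc5)cc4)nc(N4CC5CCC(C4)O5)c3s2)CC1`: 200 nM
Compound 2 `O=C(Nc1ccncc1)Nc1ccc(-c2nc(N3CC4CCC(C3)O4)c3sccc3n2)cc1`: 10 nM

Compound 2 holds the lower of the two numbers; compound 1 stands beyond the scatter above it. Among the compounds with values here, the one measured step, a 20-fold lower number from compound 1 to compound 2 (1.30 log units; beyond the scatter), came with hydrogen in place of (4-methylpiperazin-1-yl)methyl on an aromatic carbon. Compound 3 `CS(=O)(=O)N1CCN(Cc2cc3nc(-c4ccc(NC(=O)Nc5ccncc5)cc4)nc(N4CC5CCC(C4)O5)c3s2)CC1` differs from compound 2 by (4-(methylsulfonyl)piperazin-1-yl)methyl in place of hydrogen on an aromatic carbon. That step bears directly on the new one: a substituent of the same family returns to the same place, and a rise in the number is therefore expected, roughly of the size seen before, though a smaller rise cannot be excluded. The expected step is a 10-fold higher number from compound 2 to compound 3 (1.00 log units; beyond the scatter). Compound 3 is estimated at 100 nM, with a range from 30 nM to 400 nM.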

Compound 3, half-maximal inhibitory concentration: 120 nM
Beside the measured number, compound 3's estimate is 1.2-fold (0.08 log units) below it; low and high end bracket the measured number.
By their numbers in this assay, from the lowest: compound 2; then compounds 3 and 1 (each within the scatter of the next).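

In this assay the entry of (4-(methylsulfonyl)piperazin-1-yl)methyl on the aromatic carbon next to the ring sulfur gives a 12-fold higher number from compound 2 to compound 3 (1.08 log units; beyond the scatter) and so shows that the earlier rise was not confined to the methylpiperazine. Methylsulfonyl in place of methyl on the ring nitrogen gives a 1.7-fold lower number from compound 1 to compound 3 (0.22 log units; within the scatter) and leaves no readable difference between these two compounds. No measurement shown explains either step.

Still open, going by these compounds, is whether a simple aminomethyl or a morpholin-4-ylmethyl group at this place would keep the number of compound 2.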